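Butylamide series: phenyl added on the chain carbon

The source may report more compounds than this note shows. Statements on the series, on what has been measured and on what is new or still open speak of the compounds shown alone.

Compound 1 `CCCCNC(=O)c1cc(C)sc1N` is the reference point of the series. In an assay on isolated protein for inhibition of Polyunsaturated fatty acid lipoxygenase ALOX15 (Homo sapiens), read by spectrophotometry, with a stated time of 10 min (a lower number here means a stronger inhibitor, a higher number a weaker inhibitor), compound 1 gives >= 50000 nM, which is a limit of the assay and not a measured number. Among the measured compounds shown here, compound 2 `CCCCNC(=O)c1cc(-c2ccc(Br)cc2)sc1N` is the only other member measured so far. In this assay compound 2 gives >= 50000 nM, again a limit rather than a number. Both values rest on (the limit of >= 50000 nM in this assay, at which 2 of the 2 values shown sit), so compound 1 stands nowhere distinct among the numbers shown, and no step between measured compounds can be sized or given a direction.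

Compound 3 `CCCCNC(=O)c1cc(Cc2ccccc2)sc1N` is the next member to be measured. It differs from compound 1 by phenyl in place of hydrogen on a saturated chain carbon bound to an aromatic carbon. For the measured compounds named here, with no measured step to lean on, the expected step of a number no higher from compound 1 to compound 3 (the limit leaves the size open) is none beyond the scatter, with compound 3 most likely reported at the limit as well. Compound 3 is expected at 50000 nM, with a range from 12000 nM to 200000 nM.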

Compound 3, half-maximal inhibitory concentration: >= 50000 nM
Compound 3 ended at the assay's limit (the forecaster's own chance of this, stated with the estimate: 75%); the middle value sits exactly at the limit.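

No step can be read from compound 1 to compound 3 in this assay, since both values are limits of the assay and not numbers: the limit of >= 50000 nM in this assay, at which 3 of the 3 values shown sit.

The compounds shown leave open whether phenyl in place of hydrogen on a saturated chain carbon bound to an aromatic carbon changes inhibition at all, and which change to the shared core would give a measurable number.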